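The source may report more compounds than this note shows. Statements on the series, on what has been measured and on what is new or still open speak of the compounds shown alone.

Measured so far in an ADME assay on Huh7.5.1 cells (Homo sapiens) for cytotoxicity, read by ATP content, with a stated time of 48 h; on this read-out higher numbers stand for lower toxicity in this test and lower numbers for higher toxicity in this test:
- compound 1 `Cc1oc(-c2c(C)c(C)c(C)c(C)c2C)nc1CN1CCC(C(=O)NCCCN2C[C@H](C)C[C@H](C)C2)CC1` gives 8180 nM
- compound 2 `Cc1ccccc1-c1nc(CN2CCC(C(=O)NCCCN3CC4CCCC(C4)C3)CC2)c(C)o1` gives 10900 nM

Compound 1 holds the lowest of the two numbers; the nearest is compound 2, whose number lies within the scatter of it, so the two read alike here. Among the measured compounds shown here, no step between measured compounds that differ in one place is available for the series.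

Compound 3 `COc1cccc(OC)c1-c1nc(CN2CCC(C(=O)NCCCN3C[C@H](C)C[C@H](C)C3)CC2)c(C)o1` is the next candidate. The change from compound 1: 2,6-dimethoxyphenyl in place of 2,3,4,5,6-pentamethylphenyl on an aromatic carbon

Nothing measured speaks to this change, and both measured numbers sit close together, so the step is expected to stay within the scatter, about a 1.1-fold higher number from compound 1 to compound 3 (0.04 log units; within the scatter). Compound 3 is estimated at 9000 nM, with a range from 4000 nM to 22000 nM.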

Compound 3, half-maximal cytotoxic concentration: 77100 nM
Compound 3: middle estimate off by 8.6-fold (0.93 log units), on the low side; the whole stated range lies below it.
By their numbers in this assay, from the lowest: compounds 1 and 2 (each within the scatter of the next); then compound 3.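

In this assay placing 2,6-dimethoxyphenyl where 2,3,4,5,6-pentamethylphenyl stood gives a 9.4-fold higher number from compound 1 to compound 3 (0.97 log units; beyond the scatter) and shows that the aromatic carbon of the five-membered ring can move this read-out, which the two earlier compounds could not show. Nothing at hand explains the step.

Still open, going by these compounds, is whether the two methoxy groups together carry the step, or whether a single methoxy group or an unsubstituted phenyl would read the same. Also open, on these data alone, is whether the same step holds with the other amine of compound 2.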